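Moving the ring nitrogen in a fluoropyridyl analogue

The compounds below may be only part of what the source reports. "The series", "measured", "known", "first", "only" and "open" are said of these compounds alone.

In an assay on HEK293 cells for activation of Kir3.1/Kir3.2 (Homo sapiens), read by thallium flux (on this read-out lower numbers stand for smaller maximal responses and higher numbers for larger maximal responses), compound 1 `Cc1cc(NC(=O)Cn2nnc(-c3ccccc3)n2)n(C2CCCCC2)n1` gives 92%. In this assay compound 2 `Cc1cc(NC(=O)Cn2nnc(-c3cccc(F)c3)n2)n(C2CCCCC2)n1` gives 96% and compound 3 `Cc1cc(NC(=O)Cn2nnc(-c3ccnc(F)c3)n2)n(C2CCCCC2)n1` gives 95%. Compound 3 stands second highest of the three numbers, with compound 2 nearest and compound 1 furthest, and neither gap exceeds the scatter: a number 1 percentage points lower from compound 2 to compound 3 (within the scatter), a number 3 percentage points higher from compound 1 to compound 3 (within the scatter).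

Compound 4 `Cc1cc(NC(=O)Cn2nnc(-c3cccc(F)n3)n2)n(C2CCCCC2)n1`, not yet measured, differs from compound 3 by 6-fluoropyridin-2-yl in place of 2-fluoropyridin-4-yl on an aromatic carbon. Among the compounds with values here, the steps that bear on this change all vary the same aromatic group on the shared core, and every one of them stays within the scatter: a number 4 percentage points higher from compound 1 to compound 2 (within the scatter), a number 3 percentage points higher from compound 1 to compound 3 (within the scatter), a number 1 percentage points lower from compound 2 to compound 3 (within the scatter). Accordingly the step of a number 2 percentage points lower from compound 3 to compound 4 (within the scatter) is expected to stay within the scatter, with no direction beyond it. For compound 4 a value of 93% is expected, with a range from 84% to 101%.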

Compound 4, largest response reached (Emax), in percent of the reference or control that the assay uses: > 83%
Compound 4 gave a limit, no number; the forecaster's own chance of this, stated with the estimate: 0%; the middle value lies beyond the limit too.
By their numbers in this assay, from the lowest: compounds 1, 3 and 2 (each within the scatter of the next).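

In this assay compound 4 gives > 83%, a limit and not a number, so the steps to compound 4 from compound 1, compound 2 and compound 3 cannot be read. Going by these compounds, whether 6-fluoropyridin-2-yl in place of 2-fluoropyridin-4-yl alters the maximal response remains open.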